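This account rests on a few compounds, and the source may have more. Where it says the series, first, only, none or still open, it means among the compounds named here.

Values in an ADME assay on BaF3 cells (Mus musculus) for antiproliferative activity, read by CellTiter-Glo and CCK-8 assay, with a stated time of 72 h (a lower number here means a stronger inhibitor of growth, a higher number a weaker inhibitor of growth), so far:
- compound 1 `CNc1nc(Nc2ccc(C)c([N+](=O)[O-])c2)ncc1C(=O)Nc1cc(NC(=O)c2ccc(OC)c(OC)c2)ccc1C` gives 7300 nM
- compound 2 `CNc1nc(Nc2ccc(C)c([N+](=O)[O-])c2)ncc1C(=O)Nc1cc(NC(=O)c2ccc3c(c2)OCCO3)ccc1C` gives > 10000 nM (a limit of the assay, not a number)

On these data alone, compound 2 has only this limit and no measured value, so its exact standing in this assay is unknown.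

Compound 3 `CNc1nc(Nc2ccc(C)c(N)c2)ncc1C(=O)Nc1cc(NC(=O)c2ccc3c(c2)OCCO3)ccc1C` differs from compound 2 by amino in place of nitro on an aromatic carbon, ortho to a methyl group and meta to a large group (amino in place of nitro on an aromatic carbon). Among the measured compounds shown here, the one measured step, an at least 1.3-fold higher number from compound 1 to compound 2 (0.13 log units; that floor lies within the scatter), concerns a different change, 2,3-dihydro-1,4-benzodioxin-6-yl in place of 3,4-dimethoxyphenyl on a carbonyl carbon. For the measured compounds named here, it therefore gives no size for the nitro to amino exchange, and no measured step does.

Compound 2 reads > 10000 nM, which is a limit, so any number expected for compound 3 lies on the lower side of it. A further limit remains quite possible. The expected change is a modest, loosely held fall (an at least 2.0-fold lower number from compound 2 to compound 3 (0.30 log units; that floor lies within the scatter)). The estimated value for compound 3 is 5000 nM (expected range 1200 nM to 15000 nM).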

Compound 3, concentration for 50% growth inhibition: > 10000 nM
Compound 3: a limit, no number; the forecaster's own chance of this, stated with the estimate: 40%; middle value at least 2.0-fold (0.30 log units) from the limit.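

In this assay compound 3 gives > 10000 nM, a limit of the assay and not a number. No step from compound 2 to compound 3 can be read, as both compounds stand at the same limit: the limit of > 10000 nM in this assay, at which 2 of the 3 values shown sit.

The compounds shown leave open both the size and the direction of the change from nitro to amino.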